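A few compounds are considered here, and "the series" means these few. Any claim that something is new, unique, unknown or untested is made for them only; others in the source may bear on it.

Measured in a functional assay (Saphenous vein) for binding affinity, with Oryctolagus cuniculus as the target; on this read-out lower numbers stand for tighter binding and higher numbers for weaker binding:
- compound 1 `Cc1nc(Cc2ccc3[nH]cc([C@H]4C[C@H](N(C)C)C4)c3c2)n[nH]1`: 6610 nM
- compound 2 `CN(C)[C@H]1C[C@H](c2c[nH]c3ccc(CN4C(=O)CNC4=O)cc32)C1`: 9330 nM

Among the measured compounds shown here, with only two numbers available, compound 2 at 9330 nM cannot be told apart from compound 1 at 6610 nM, since the two lie within the usual scatter of each other.

The next compound, compound 3 `Cc1noc(-c2ccc3[nH]cc([C@H]4C[C@H](N(C)C)C4)c3c2)n1`, changes compound 2 as follows: 3-methyl-1,2,4-oxadiazol-5-yl in place of (2,5-dioxoimidazolidin-1-yl)methyl on an aromatic carbon. In words, 3-methyl-1,2,4-oxadiazol-5-yl takes the place of (2,5-dioxoimidazolidin-1-yl)methyl on an aromatic carbon.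

For the measured compounds named here, only one measured step bears on this, and only in part: a 1.4-fold higher number from compound 1 to compound 2 (0.15 log units; within the scatter). That exchange of groups on a saturated chain carbon left this assay within the scatter. Neither measured compound, however, has its five-membered ring directly on an aromatic carbon, so the data do not cover that part of the change. A step beyond the scatter is therefore not expected, though confidence is limited and the range must stay wide in both directions. The expected step is a 1.6-fold lower number from compound 2 to compound 3 (0.19 log units; within the scatter). For compound 3 the estimated value is 6000 nM, with an expected range from 1500 nM to 20000 nM.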

Compound 3, dissociation constant: 955 nM
The estimate for compound 3 lay 6.3-fold (0.80 log units) above the measured number; the measured number lies below the stated range.
By their numbers in this assay, from the lowest: compound 3; then compounds 1 and 2 (each within the scatter of the next).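

In this assay, the group on this aromatic carbon clearly matters: 3-methyl-1,2,4-oxadiazol-5-yl in place of (2,5-dioxoimidazolidin-1-yl)methyl gives a 9.8-fold lower number from compound 2 to compound 3 (0.99 log units; beyond the scatter), and in place of (5-methyl-1H-1,2,4-triazol-3-yl)methyl it gives a 6.9-fold lower number from compound 1 to compound 3 (0.84 log units; beyond the scatter). The earlier exchange between the two groups held on a saturated chain carbon had stayed within the scatter, so the position looked tolerant of change, and the new result shows that this holds only among those two groups, not for the position as a whole. Nothing at hand explains why the number falls with this change.

Each new step changes the ring and removes the saturated chain carbon at once, so the compounds shown leave open which of the two accounts for the lower number; a (3-methyl-1,2,4-oxadiazol-5-yl)methyl group, or a 5-methyl-1H-1,2,4-triazol-3-yl group on the aromatic carbon itself, would separate them. Also open, going by these compounds, is whether the lower number is particular to the 3-methyl-1,2,4-oxadiazol-5-yl ring or extends to a simple amide or a nitrile on the same aromatic carbon.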